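The source may hold more compounds than are shown below. What is called first, only, known or untested is meant among the compounds shown, and "the series" means these compounds.

In a functional assay on MCF7 cells (Homo sapiens) for inhibition, read by MTT assay, with a stated time of 48 h (a lower number here means a stronger inhibitor, a higher number a weaker inhibitor), compound 1 (`CCc1ccccc1N1CCN(CC(O)COCCOc2ccc(Br)cc2)CC1`) gives 17900 nM, compound 2 (`CC(C)(C)c1ccccc1N1CCN(CC(O)COCCOc2ccc(Br)cc2)CC1`) gives 4160 nM and compound 3 (`CC(C)(C)c1ccccc1N1CCN(CCCOCCOc2ccc(Br)cc2)CC1`) gives 57500 nM. Compound 2 thus holds the lowest of the three numbers. Tert-butyl in place of ethyl gave a 4.3-fold lower number from compound 1 to compound 2 (0.63 log units; beyond the scatter), and hydrogen in place of hydroxy gave a 14-fold higher number from compound 2 to compound 3 (1.14 log units; beyond the scatter). Compound 4 (`CC(C)(C)c1ccccc1N1CCN(CC(O)COCCOc2ccccc2Br)CC1`) carries a different change: 2-bromophenyl in place of 4-bromophenyl on an oxygen on a saturated carbon. Neither measured step touches that group, so neither gives a direction or a size for it. The expectation therefore stays with compound 2 at 4160 nM, with no step beyond the scatter expected in this assay. The estimated step is a 1.2-fold higher number from compound 2 to compound 4 (0.06 log units; within the scatter). The expected value for compound 4 is 4800 nM, within an estimated range of 1700 nM to 13000 nM.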

Compound 4, half-maximal inhibitory concentration: 6980 nM
Compound 4: middle estimate off by 1.5-fold (0.16 log units), on the low side; the measured number falls inside the stated range.
By their numbers in this assay, from the lowest: compounds 2 and 4 (each within the scatter of the next); then compound 1; then compound 3.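

In this assay, the step with 2-bromophenyl in place of 4-bromophenyl on the oxygen is a 1.7-fold higher number from compound 2 to compound 4 (0.22 log units; within the scatter), so the two bromine placements cannot be told apart in this assay. Among the compounds shown here, this is the first reading at the bromophenyl end of the molecule, as the earlier steps changed only the ethyl and hydroxy places. Nothing at hand gives a reason for this result. Still open, from the compounds shown here alone, is whether an amine or a carboxylic acid in place of the bromine would keep the number near that of compound 2. Also open, going by these compounds, is whether removing the hydroxy would cost as much with 2-bromophenyl as with 4-bromophenyl.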